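A Trifluoromethyl Added to Compound 1

The compounds below may be only part of what the source reports. "The series", "measured", "known", "first", "only" and "open" are said of these compounds alone.

Of the compounds shown here, three built on one shared core have been tested in a functional assay on MDA-MB-231 cells (Homo sapiens) for antiproliferative activity, read by MTT assay; a lower number here means a stronger inhibitor, a higher number a weaker inhibitor. Compound 1 `CNC(=O)c1ccc(Oc2cccc(NC(=S)Nc3ccc(Cl)cc3)c2)nc1` gives 66500 nM, compound 2 `CNC(=O)c1ccc(Oc2cccc(NC(=S)Nc3ccc(F)c(F)c3)c2)nc1` gives 69300 nM, and compound 3 `CNC(=O)c1ccc(Oc2cccc(NC(=S)Nc3ccc(OC)cc3)c2)nc1` gives 31500 nM. Among these three numbers compound 1 holds the second highest place; compound 2 lies closest to it, and compound 3 lies furthest away.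

The measured steps are small. Swapping one halogenated ring for another gave a 1.0-fold higher number from compound 1 to compound 2 (0.02 log units; within the scatter). Replacing the chloro by methoxy gave a 2.1-fold lower number from compound 1 to compound 3 (0.32 log units; beyond the scatter), and the corresponding change from compound 2 gave a 2.2-fold lower number from compound 2 to compound 3 (0.34 log units; beyond the scatter), both modest lowerings.

Compound 4 `CNC(=O)c1ccc(Oc2cccc(NC(=S)Nc3ccc(Cl)c(C(F)(F)F)c3)c2)nc1` differs from compound 1 by trifluoromethyl in place of hydrogen on an aromatic carbon. Within the data shown here, the chloro of compound 1 is kept, so none of the measured steps describes this change directly; the closest guide is the step from compound 1 to compound 2, where a change among halogen substituents on that ring left the number within the scatter. On that basis no step beyond the scatter is expected in this assay.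

Compound 4 is therefore expected to give about 60000 nM in this assay, within a range from 25000 nM to 150000 nM. The expected step is a 1.1-fold lower number from compound 1 to compound 4 (0.04 log units; within the scatter).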

Compound 4, half-maximal inhibitory concentration: 2330 nM
Estimate against measurement, compound 4: 26-fold (1.41 log units) above; measured number below the stated range.
By their numbers in this assay, from the lowest: compound 4; then compound 3; then compounds 1 and 2 (each within the scatter of the next).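

In this assay, among these compounds, adding trifluoromethyl on an aromatic carbon ortho to a chloro group gives a 29-fold lower number from compound 1 to compound 4 (1.46 log units; beyond the scatter) and so moves the number much further than any step among the earlier compounds. Those compounds showed only small movements, and the change to the 3,4-difluorophenyl ring gave a 1.0-fold higher number from compound 1 to compound 2 (0.02 log units; within the scatter) so a second substituent on this ring does not by itself lower the number; compound 4 shows that with trifluoromethyl as that second substituent, the number can fall sharply. No measurement shown here accounts for the size of this step.

As far as these compounds go, whether a methyl, a nitrile or a bromo on this same carbon would lower the number as far remains open, as does whether trifluoromethyl would do so without the chloro group. From the compounds shown here alone, it is also open whether trifluoromethyl and the methoxy of compound 3 would work together on one ring, or whether the lower number seen with compound 4 would hold in cells other than those of this assay.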